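From methoxy to fluoro in compound 4

The source may report more compounds than this note shows. Statements on the series, on what has been measured and on what is new or still open speak of the compounds shown alone.

Measured so far in a functional assay on HeLa cells (Homo sapiens) for antiproliferative activity, read by MTT assay, with a stated time of 24 h; a higher number here means a weaker inhibitor, a lower number a stronger inhibitor
- compound 1 `Cc1ccc(-c2nn(-c3ccccc3)cc2-c2nc3ccccc3[nH]2)cc1` gives 4950 nM
- compound 2 `Cc1ccc(-c2nn(-c3ccccc3)cc2-c2nc3ccccc3n2S(=O)(=O)c2ccc(F)cc2)cc1` gives 3670 nM
- compound 3 `COc1ccc(S(=O)(=O)n2c(-c3cn(-c4ccccc4)nc3-c3ccc(F)cc3)nc3ccccc32)cc1` gives 390 nM

Compound 3 has the lowest number of the three, which makes it the strongest inhibitor in this small set. Compound 4 `O=S(=O)(c1ccc(F)cc1)n1c(-c2cn(-c3ccccc3)nc2-c2ccc(F)cc2)nc2ccccc21` differs from it in one place: fluoro in place of methoxy on an aromatic carbon, so that (4-methoxyphenyl)sulfonyl becomes (4-fluorophenyl)sulfonyl.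

Among the measured compounds shown here, no measured pair makes this exact swap. For the measured compounds named here, the only single-place step is a 1.3-fold lower number from compound 1 to compound 2 (0.13 log units; within the scatter), where (4-fluorophenyl)sulfonyl replaces hydrogen on an aromatic nitrogen, so it bears on the swap only loosely. Going by the values given here, compound 2, which carries that same group, gives 3670 nM, a clearly higher number than the one for compound 3. This evidence is indirect, but it points towards a rise in this assay rather than a fall. The expected change is moderate: a 2.1-fold higher number from compound 3 to compound 4 (0.31 log units; beyond the scatter). For compound 4 the estimated value is 800 nM, with an expected range from 250 nM to 2800 nM.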

Compound 4, half-maximal inhibitory concentration: 2440 nM
Compound 4: middle estimate off by 3.1-fold (0.48 log units), on the low side; low and high end bracket the measured number.
By their numbers in this assay, from the lowest: compound 3; then compounds 4, 2 and 1 (each within the scatter of the next, the first and the last beyond it).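

In this assay the swap at this place, on the aromatic carbon of the sulfonyl-bound ring, now has a direct reading: it gives a 6.3-fold higher number from compound 3 to compound 4 (0.80 log units; beyond the scatter) for the change from 4-methoxyphenyl to 4-fluorophenyl, so the two groups are not interchangeable here. The change of methyl to fluoro at another aromatic carbon gives a 1.5-fold lower number from compound 2 to compound 4 (0.18 log units; within the scatter) and cannot be told from the scatter, so only the methoxy swap stands out among these steps. No measurement to hand gives a reason for the gap between methoxy and fluoro.

Still open is whether the lower number belongs to methoxy in particular, since ethoxy, hydroxy or an amine at this place do not appear among the compounds shown. Also open, on these data alone, is whether the methoxy step holds when the other ring carries methyl instead of fluoro.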